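A few compounds are considered here, and "the series" means these few. Any claim that something is new, unique, unknown or untested is made for them only; others in the source may bear on it.

Measured in an ADME assay on microsomes from liver (Rattus norvegicus) for metabolic stability; on this read-out lower numbers stand for a less stable compound and higher numbers for a more stable compound:
- Compound 1 `C/C(CN)=C(/F)CN(C[C@H]1Cc2ccccc2CN1)[C@H]1CCCc2cccnc21`: 72%
- Compound 2 `C/C(CN)=C(\F)CN(C[C@H]1Cc2ccccc2CN1)[C@H]1CCCc2cccnc21`: 2%

Of these two, compound 2 stands lowest, at 2%, far under compound 1. Compound 3 `C/C(CN(C[C@H]1Cc2ccccc2CN1)[C@H]1CCCc2cccnc21)=C(\F)CN` has the same atoms as compound 2, joined differently: 3-amino-2-fluoro-1-methylprop-1-en-1-yl in place of 2-(aminomethyl)-1-fluoroprop-1-en-1-yl on a saturated chain carbon bound to an amine nitrogen. Going by the values given here, only one measured step bears on this change, and only indirectly. It is a number 70 percentage points lower from compound 1 to compound 2 (beyond the scatter), a large step that comes with the fact that compounds 1 and 2 differ only in the configuration as drawn. That step involves no rearrangement of the chain, but it shows that this read-out can swing widely in this series without any change of atoms. With compound 2 at 2%, little room remains below it, so any step beyond the scatter is expected to go upward. The estimated step is a number 23 percentage points higher from compound 2 to compound 3 (beyond the scatter), and its size is quite uncertain. For compound 3 the expected value is 25%, within an estimated range of 3% to 70%.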

Compound 3, percent of the compound remaining: 6%
For compound 3 the middle estimate is 19 percentage points above the measured one; the range from low to high includes it.
By their numbers in this assay, from the lowest: compounds 2 and 3 (each within the scatter of the next); then compound 1.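

In this assay, placing 3-amino-2-fluoro-1-methylprop-1-en-1-yl where compound 2 carries 2-(aminomethyl)-1-fluoroprop-1-en-1-yl, on a saturated chain carbon bound to an amine nitrogen, gives a number 4 percentage points higher from compound 2 to compound 3 (within the scatter), so this rearrangement of the same atoms leaves no difference that the read-out can separate. Read against the other double-bond isomer, the same change gives a number 66 percentage points lower from compound 1 to compound 3 (beyond the scatter), so compound 3 does not share the high number of compound 1. Among these three compounds, the high number therefore stays with compound 1 alone, and the atoms present do not settle it: the fact that compounds 1 and 2 differ only in the configuration as drawn

From the compounds shown here alone, it remains open whether compound 3 with its double bond drawn the other way would reach a number like that of compound 1. Going by these compounds, it also remains open how a saturated chain in place of the double bond, or chlorine in place of fluorine, would read in this assay.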